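The source may hold more compounds than are shown below. What is called first, only, known or untested is meant among the compounds shown, and "the series" means these compounds.

Compound 1 `C#CCNC(=O)c1cccc2c1cc(C)n2-c1nc2c(c(NCc3ccccc3)n1)COCC2` gives 1080 nM in a functional assay on MIA PaCa-2 cells (Homo sapiens) for antiproliferative activity; a lower number here means that less compound is needed, a higher number that more compound is needed for the effect. Compound 2 `CC#CCNC(=O)c1cccc2c1cc(C)n2-c1nc2c(c(NCc3ccccc3)n1)COCC2` differs from it by methyl in place of hydrogen on a triple-bonded carbon, and the step of a 2.1-fold lower number from compound 1 to compound 2 (0.31 log units; beyond the scatter). Compound 3 `CC#CC(=O)Nc1cccc2c1cc(C)n2-c1nc2c(c(NCc3ccccc3)n1)CCCC2` has a different core; the difference between the two cores is not broken down here. In this assay compound 3 gives 436 nM, and compound 2 gives 524 nM, the two values lying within the scatter of each other, while compound 1 sits beyond the scatter above compound 3.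

Compound 4 `CCC#CC(=O)Nc1cccc2c1cc(C)n2-c1nc2c(c(NCc3ccccc3)n1)CCCC2` differs from compound 3 by methyl in place of hydrogen on a saturated chain carbon bound to a triple-bonded carbon. It is the same kind of change as that from compound 1 to compound 2, but the place differs: there the methyl entered on a triple-bonded carbon whose other neighbour is a triple-bonded carbon, here on a saturated chain carbon bound to a triple-bonded carbon. Because compound 1 to compound 2 gave a 2.1-fold lower number from compound 1 to compound 2 (0.31 log units; beyond the scatter), a step in the same direction but of smaller size is expected for compound 4, namely a 1.5-fold lower number from compound 3 to compound 4 (0.16 log units; within the scatter). Compound 4 is thus estimated at 300 nM, with a likely range from 150 nM to 700 nM.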

Compound 4, half-maximal effective concentration: 463 nM
Estimate against measurement, compound 4: 1.5-fold (0.19 log units) below, and the stated range covers the measured number.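

In this assay the methyl on a saturated chain carbon bound to a triple-bonded carbon gives a 1.1-fold higher number from compound 3 to compound 4 (0.03 log units; within the scatter), a step that by itself shows no effect of the change on the core of compound 3. Set beside a 2.1-fold lower number from compound 1 to compound 2 (0.31 log units; beyond the scatter), it might suggest that the methyl counts on one core and not on the other, yet the two steps cannot be told apart: the same change on two cores in this assay, a 2.1-fold lower number (0.31 log units; beyond the scatter) from compound 1 to compound 2 and a 1.1-fold higher number (0.03 log units; within the scatter) from compound 3 to compound 4, 2.2-fold (0.34 log units) apart, within the scatter of two such steps. This shows no difference between the cores, but it does not show that the change carries over unaltered, since each core offers a single pair and the methyl sits at a different place in each.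

The compounds shown leave open how a chain longer than but-1-yn-1-yl, or an amine at the end of that chain, would read in this assay. They also leave open what a methyl on a saturated chain carbon bound to a triple-bonded carbon would give on the core of compound 1.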